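The compounds below may be only part of what the source reports. "The series", "measured", "known", "first", "only" and "open" are said of these compounds alone.

For the measured compounds named here, compound 3 `c1ccc(C2=NN(C3=NC(c4ccccc4)CS3)C(c3cccc4ccccc34)C2)cc1` gives 5320 nM in a functional assay on HeLa cells (Homo sapiens) for inhibition, read by CCK-8 assay, with a stated time of 48 h (on this read-out higher numbers stand for weaker inhibition and lower numbers for stronger inhibition), the second highest of the three numbers measured so far. Compound 1 `Fc1ccc(C2=NN(C3=NC(c4ccccc4)CS3)C(c3cccc4ccccc34)C2)cc1` gives 12400 nM and compound 2 `Cc1ccc(C2=NN(C3=NC(=O)CS3)C(c3cccc4ccccc34)C2)cc1` gives 3210 nM; the step of a 2.3-fold lower number from compound 1 to compound 3 (0.37 log units; beyond the scatter) lies beyond the scatter, whereas compound 3 and compound 2 sit within the scatter of each other. Compound 4 `Cc1ccc(C2=NN(C3=NC(c4ccccc4)CS3)C(c3cccc4ccccc34)C2)cc1` differs from compound 3 by methyl in place of hydrogen on an aromatic carbon. Going by the values given here, no measured step exchanges hydrogen for methyl on that aromatic carbon; the only step there, a 2.3-fold lower number from compound 1 to compound 3 (0.37 log units; beyond the scatter), concerns fluoro, and compound 2 carries the methyl together with a second change, so it offers no clean comparison. The step to compound 4 is therefore expected to stay small, a 1.3-fold lower number from compound 3 to compound 4 (0.12 log units; within the scatter), with no firm direction. Compound 4 is estimated at 4000 nM, between 1500 nM and 12000 nM.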

Compound 4, half-maximal inhibitory concentration: 4290 nM
Compound 4: the middle estimate sits 1.1-fold (0.03 log units) below what was measured; the range from low to high includes it.
By their numbers in this assay, from the lowest: compounds 2, 4 and 3 (each within the scatter of the next); then compound 1.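

Methyl in place of hydrogen, the phenyl to 4-methylphenyl change, gives the first clean reading at this place and stays within the scatter (a 1.2-fold lower number from compound 3 to compound 4 (0.09 log units; within the scatter)). Fluoro now stands apart from methyl as well as from hydrogen, with the methyl step beyond the scatter (a 2.9-fold lower number from compound 1 to compound 4 (0.46 log units; beyond the scatter)). With the 4-methylphenyl held constant, exchanging the group on the amine nitrogen also stays within the scatter (a 1.3-fold higher number from compound 2 to compound 4 (0.13 log units; within the scatter)).

No measured evidence accounts for these steps. From the compounds shown here alone, whether a chloro, methoxy or amine group at this place would track fluoro or methyl remains open.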